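Compound 4 Expected Near the Measured Cytotoxicity Level

The compounds below may be only part of what the source reports. "The series", "measured", "known", "first", "only" and "open" are said of these compounds alone.

The measured compounds:
compound 1 `COc1cc(NC(C)CCCNC(=O)/C=C/c2ccc(Cl)cc2)c2ncccc2c1`: 16800 nM
compound 2 `COc1cc(NC(C)CCCNC(=O)/C=C/c2cccc(C(F)(F)F)c2)c2ncccc2c1`: 16200 nM
compound 3 `COc1cc(NC(C)CCCNC(=O)Nc2ccc(Cl)c(C(F)(F)F)c2)c2ncccc2c1`: "not determined" (no result reported)
compound 4 `COc1cc(NC(C)CCCNC(=O)NNC(=O)Nc2ccc(Cl)cc2)c2ncccc2c1`: not yet measured

In an ADME assay on L6 cells (Rattus norvegicus) for cytotoxicity, read by resazurin assay, with a stated time of 70 h (a lower number here means a stronger inhibitor, a higher number a weaker inhibitor), compound 1 gives 16800 nM, and compound 2 gives 16200 nM. Among the compounds with values here, the only measured step, a 1.0-fold lower number from compound 1 to compound 2 (0.02 log units; within the scatter), lies within the scatter, so the two compounds sit at one level. In this assay compound 3 gives "not determined" (no result reported) and therefore stands nowhere on the numbers shown.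

Compound 4 differs from compound 3 by ((4-chlorophenyl)carbamoyl)amino in place of 4-chloro-3-(trifluoromethyl)phenyl on an amide-type nitrogen. Within the data shown here, no measured step bears on this change: the single recorded step concerns a different part of compounds 1 and 2, and compound 3 itself has no number from which a step could be counted. What can be said rests on compounds 1 and 2, which share the core and the chain with compound 4 and both give numbers close to each other in this assay. On that basis compound 4 is expected to give about 16000 nM in this assay, with a range from 5000 nM to 50000 nM.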

Compound 4, half-maximal inhibitory concentration: 91900 nM
For compound 4 the middle estimate is 5.7-fold (0.76 log units) below the measured one; measured number outside the range, above it.
By their numbers in this assay, from the lowest: compounds 2 and 1 (each within the scatter of the next); then compound 4.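

In this assay compound 4 gives 91900 nM, but no new step can be read, as compound 3 offers no number to count from. No data shown explain this value. Left open is how ((4-chlorophenyl)carbamoyl)amino in place of 4-chloro-3-(trifluoromethyl)phenyl shifts the number in this assay.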